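Cytotoxicity in a sulfonyl amidoxime series: extending compound 2

A few compounds are considered here, and "the series" means these few. Any claim that something is new, unique, unknown or untested is made for them only; others in the source may bear on it.

Three members of the series have numbers in an ADME assay on THP-1 cells (Homo sapiens) for cytotoxicity, read by flow cytometry, with a stated time of 72 h; on this read-out lower numbers stand for stronger inhibition and higher numbers for weaker inhibition. Compound 1 `N/C(=N\O)c1ccc(S(=O)(=O)CC(=O)c2ccccc2)cc1` sits at the limit of the assay, giving > 125000 nM in this assay; this is a limit, not a number (the limit of > 125000 nM in this assay, at which 1 of the 3 values shown sits). Compound 2 `N/C(=N\O)c1ccc(C2=C(S(=O)(=O)c3ccccc3)CC(c3ccccc3)(c3ccccc3)O2)cc1` gives 30600 nM in this assay, the lowest of the two numbers that were obtained. Compound 3 `CC1(c2ccccc2)CC(S(=O)(=O)c2ccc(/C(N)=N/O)cc2)=C(c2ccc(/C(N)=N/O)cc2)O1` gives 99500 nM in this assay, a value that is higher than that of compound 2 by more than the usual scatter, though the two structures differ in more than one place, so the two values are simply reported side by side.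

Compound 4 `N/C(=N\O)c1ccc(/C=C/c2ccc(S(=O)(=O)C3=C(c4ccc(/C(N)=N/O)cc4)OC(c4ccccc4)(c4ccccc4)C3)cc2)cc1` has not yet been measured in this assay. It differs from compound 2 by a group of 12 heavy atoms (9 carbon, 2 nitrogen, 1 oxygen; one six-membered aromatic ring of carbon only) in place of a hydrogen atom, on an aromatic carbon, para to a large group. Going by the values given here, no single-place step between measured compounds is available to anchor this change. The expectation is a step from compound 2 to compound 4 of a 1.3-fold higher number from compound 2 to compound 4 (0.12 log units; within the scatter), small and toward a weaker number, but plausibly within the scatter. Compound 4 is therefore estimated at 40000 nM in this assay, in a range from 15000 nM to 110000 nM.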

Compound 4, half-maximal inhibitory concentration: > 10000 nM
Compound 4: only a limit was reported; the forecaster's own chance of this, stated with the estimate: 15%; the middle value is on the limit's open side.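

Compound 4 gives > 10000 nM, which is a limit and not a number. No step from compound 2 to compound 4 can be read from this result: the limit of > 10000 nM in this assay, at which 1 of the 4 values shown sits.

The compounds shown leave open whether the group of 12 heavy atoms in place of a hydrogen atom changes the number relative to compound 2, and in which direction.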